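This account rests on a few compounds, and the source may have more. Where it says the series, first, only, none or still open, it means among the compounds named here.

Compound 1 `CCOCCOc1nc(C(C)(C)C)ccc1CNC(=O)C(C)c1ccc(NS(C)(=O)=O)c(F)c1` and compound 2 `CC(C(=O)NCc1ccc(C(C)(C)C)cc1N1CCN(c2ccccc2)CC1)c1ccc(NS(C)(=O)=O)c(F)c1` share a common core and are compared in an assay on cells for antagonist activity at transient receptor potential cation channel subfamily V member 1 (Homo sapiens), read by FLIPR and calcium flux, with a stated time of 6 min; on this read-out higher numbers stand for weaker inhibition and lower numbers for stronger inhibition. In this assay compound 1 gives 23.9 nM. Compound 2 gives 0.8 nM, the lowest of the two numbers recorded so far, and the gap to compound 1, which sits at a much higher number, lies well beyond the usual scatter of repeated measurements, so compound 2 counts as the stronger inhibitor of the pair.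

Compound 3 `CC(C(=O)NCc1ccc(C(C)(C)C)cc1OC1CCCC1)c1ccc(NS(C)(=O)=O)c(F)c1` has not yet been measured. It differs from compound 2 in one place: cyclopentyloxy in place of 4-phenylpiperazin-1-yl on an aromatic carbon. Going by the values given here, no step between two measured compounds matches this exchange, so nothing measured tells how the replacement of 4-phenylpiperazin-1-yl by cyclopentyloxy will play out; the expectation rests on the two numbers and the change alone. The step of a 6.3-fold higher number from compound 2 to compound 3 (0.80 log units; beyond the scatter) is expected to point toward weaker inhibition, by a margin larger than the scatter, since the group that accompanies the lowest number is the one removed. Compound 3 is estimated at 5 nM, with a likely range from 1.5 nM to 20 nM.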

Compound 3, inhibition constant: 1.8 nM
Estimate against measurement, compound 3: 2.8-fold (0.44 log units) above, and the stated range covers the measured number.
By their numbers in this assay, from the lowest: compound 2; then compound 3; then compound 1.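

In this assay, cyclopentyloxy in place of 4-phenylpiperazin-1-yl gives a 2.3-fold higher number from compound 2 to compound 3 (0.35 log units; beyond the scatter), a modest step toward weaker inhibition, though one that lies beyond the usual scatter. The position therefore responds to the exchange, but it does not lose most of its strength. The group that enters has fewer heavy atoms, one ring instead of two, and an oxygen instead of two nitrogens, so in this pair neither the phenyl ring nor the piperazine ring is needed for a low number at this spot, on an aromatic carbon ortho to a large group and meta to a tert-butyl group.

A single pair cannot separate the roles of the ring and of the atom that joins it to the aromatic carbon, a question that cyclohexyloxy, an open-chain isopropoxy or a directly attached piperidin-1-yl would address at the same position. On these data alone, it also remains open whether the same exchange would play out alike on the core of compound 1, and no measurement at hand gives a reason for the step.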